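This account rests on a few compounds, and the source may have more. Where it says the series, first, only, none or still open, it means among the compounds named here.

Working notes on the series. In a functional assay on HCT-116 cells (Homo sapiens) for cytotoxicity, read by scintillation counting and thymidine incorporation, with a stated time of 72 h (a higher number here means a weaker inhibitor, a lower number a stronger inhibitor), compound 1 (`CCOc1cc(C(=CC#N)c2ccc(OC)c(N)c2)ccc1OC`) gives 19 nM, compound 2 (`COc1cc(OC)cc(C(=CC#N)c2ccc(OC)c(OC)c2)c1`) gives 18 nM and compound 3 (`COc1cc(OC)cc(/C(=C\C#N)c2ccc(OC)c(OC)c2)c1`) gives 11 nM. Compound 3 stands within the scatter of both other compounds, so these numbers do not set it apart.

The next comparison is with compound 4 (`COc1cc(OC)cc(/C(=C/C#N)c2ccc(OC)c(OC)c2)c1`), and the change is the two compounds have the same atoms and bonds and differ only in configuration as drawn: 1 of 1 stereo elements differ; a double bond is drawn Z in compound 3 and E in compound 4. The two compounds have the same atoms and bonds, and the double bond is drawn Z in compound 3 and E in compound 4.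

Among the compounds with values here, only one measured step bears on this: a 1.6-fold lower number from compound 2 to compound 3 (0.21 log units; within the scatter). That step is within the scatter and goes with the fact that one of compounds 2 and 3 is drawn with a defined configuration and the other without, at the place where they differ. It is also indirect, since compound 2 has no configuration drawn and the data do not show what it contains. Within the data shown here, no measured step runs from a Z compound to an E compound. The small step to compound 3 therefore gives only a faint lean, and a higher number is expected for compound 4, with a wide margin on the high side.

The expected change is a 3.6-fold higher number from compound 3 to compound 4 (0.56 log units; beyond the scatter). Compound 4 is estimated at 40 nM in this assay, with an expected range of 12 nM to 250 nM.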

Compound 4, half-maximal inhibitory concentration: 110 nM
Compound 4: middle estimate off by 2.8-fold (0.44 log units), on the low side, within the range that was stated.
By their numbers in this assay, from the lowest: compounds 3, 2 and 1 (each within the scatter of the next); then compound 4.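

In this assay, within the data shown here, the series now has a measured step from a Z compound to an E compound, a 10-fold higher number from compound 3 to compound 4 (1.00 log units; beyond the scatter), and it lies beyond the scatter, so the drawn geometry of this double bond separates the two numbers, which the earlier compounds could not show. Nothing else changes in this pair, and the step can be attributed to configuration alone: the fact that compounds 3 and 4 differ only in the configuration as drawn

Compound 2, drawn without a configuration at the same double bond, gives a matching picture, with a 6.1-fold higher number from compound 2 to compound 4 (0.79 log units; beyond the scatter), whereas a 1.6-fold lower number from compound 2 to compound 3 (0.21 log units; within the scatter), so its number stays within the scatter of the Z compound and apart from the E compound, though what compound 2 contains is still not shown. The preference for Z over E rests on this single pair and is no general rule for the series.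

The compounds shown leave open whether the same gap between Z and E appears with the amine and ethoxy groups of compound 1, which is drawn without a configuration. They also leave open whether it survives when the nitrile gives way to a carboxylic acid or a primary amide.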